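Pyridinyl Ether to Pyridinyl Thioether in a Glutamate Receptor Series

This account rests on a few compounds, and the source may have more. Where it says the series, first, only, none or still open, it means among the compounds named here.

Within the data shown here, compound 3 `Cc1c(OCCCCOc2ccncc2)ccc(C(=O)CC(C)C)c1O` gives 3860 nM in a functional assay for binding affinity to metabotropic glutamate receptor 2 (Homo sapiens), read by GTPgammaS binding (a lower number here means that less compound is needed, a higher number that more compound is needed for the effect), the highest of the three numbers measured so far: compound 2 `Cc1c(OCCCCOc2cccnc2)ccc(C(=O)CC(C)C)c1O` gives 1720 nM and compound 1 `Cc1c(OCCCCOc2cccc(F)c2F)ccc(C(=O)CC(C)C)c1O` gives 384 nM. The steps of a 2.2-fold higher number from compound 2 to compound 3 (0.35 log units; beyond the scatter) and a 10-fold higher number from compound 1 to compound 3 (1.00 log units; beyond the scatter) place compound 3 at the weak end of the set. Compound 4 `Cc1c(OCCCCSc2cccnc2)ccc(C(=O)CC(C)C)c1O` differs from compound 3 by (pyridin-3-yl)sulfanyl in place of (pyridin-4-yl)oxy on a saturated chain carbon, four bonds along the chain from an oxygen on an aromatic ring. Among the measured compounds shown here, only the step from compound 2 to compound 3 bears on this change, and it ran against the pyridin-4-yl ring; no measured pair shows oxygen against sulfur at this position, so that part of the change is unanchored. The expected step is therefore a 2.1-fold lower number from compound 3 to compound 4 (0.33 log units; beyond the scatter), a modest move back toward the level of compound 2. Compound 4 is thus estimated at 1800 nM, within a range from 600 nM to 5400 nM.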

Compound 4, half-maximal effective concentration: 1090 nM
Compound 4: the middle estimate sits 1.7-fold (0.22 log units) above what was measured; measured number inside the range.
By their numbers in this assay, from the lowest: compound 1; then compounds 4 and 2 (each within the scatter of the next); then compound 3.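

In this assay, among these compounds, the result gives the first comparison of oxygen with sulfur at this position: with the pyridin-3-yl ring held, a 1.6-fold lower number from compound 2 to compound 4 (0.20 log units; within the scatter) lies within the scatter, so the two linking atoms cannot be told apart here. The larger 3.5-fold lower number from compound 3 to compound 4 (0.55 log units; beyond the scatter) changes ring and linking atom together, while a 2.8-fold higher number from compound 1 to compound 4 (0.45 log units; beyond the scatter) leaves the 2,3-difluorophenoxy compound ahead. No measured evidence bears on the reason for these steps.

On these data alone, whether sulfur gives the same result with a pyridin-4-yl or 2,3-difluorophenyl ring remains open. So does the effect of an amine linker or a longer chain.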